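Replacing a nonyl by 4-cyanophenyl on a shared nucleoside core

The source may report more compounds than this note shows. Statements on the series, on what has been measured and on what is new or still open speak of the compounds shown alone.

Measured compounds:
compound 1 `Nc1nc(O)c2c(n1)n(C1OC(CO)[C@@H](O)[C@H]1O)c(=O)n2CC(O)CN1CCN(c2ccc(F)cc2)CC1` gives 16%
compound 2 `CCCCCCCCCCn1c(=O)n(C2OC(CO)[C@@H](O)[C@H]2O)c2nc(N)nc(O)c21` gives 0%
compound 3 `C=CCn1c(=S)n(C2OC(COC(C)=O)[C@H]3OC(C)(C)O[C@@H]23)c2nc(N)nc(O)c21` gives 141%

Of the compounds shown here, three on a shared core have been measured in a functional assay on the whole organism (B cells) with Mus musculus as the target; a lower number here means a smaller maximal response, a higher number a larger maximal response. Compound 2 stands lowest of the three, with 0%. The nearest to it is compound 1, whose 16% lies beyond the usual scatter above it, and the furthest is compound 3, whose 141% lies far above both. No pair among these three differs in only one place, so no single step is known.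

The compound yet to be measured is compound 4 `N#Cc1ccc(Cn2c(=O)n(C3OC(CO)[C@@H](O)[C@H]3O)c3nc(N)nc(O)c32)cc1`. Its difference from compound 2 is 4-cyanophenyl in place of nonyl on a saturated chain carbon bound to an aromatic nitrogen. The decyl chain of compound 2 is thus exchanged for a 4-cyanobenzyl group bound to the same aromatic nitrogen.

The measured numbers show that the group at this position carries much of the spread, since compound 2 with its long chain gives the lowest value and compound 3 with a short allyl group gives the highest. A sizeable upward step is expected for the change, but its exact size is uncertain. The estimated step of a number 60 percentage points higher from compound 2 to compound 4 (beyond the scatter) is expected to lie beyond the scatter. For compound 4 the estimate in this assay is 60%, with a range from 10% to 130%.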

Compound 4, largest response reached (reported as maximal response), in percent of the reference or control that the assay uses: 50%
Estimate against measurement, compound 4: 10 percentage points above, and the stated range covers the measured number.
By their numbers in this assay, from the lowest: compound 2; then compound 1; then compound 4; then compound 3.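

In this assay, among the compounds shown here, exchanging the decyl chain for 4-cyanobenzyl on the same aromatic nitrogen gives a number 50 percentage points higher from compound 2 to compound 4 (beyond the scatter), the first step between compounds that differ in one place. For the compounds shown here, it shows that this place alone, with the rest of the shared core held constant, can move the maximal response by a large amount, which the earlier compounds could only hint at. None of the data shown offers an explanation for the size of this step.

The change brings in an aromatic ring and a nitrile together, so this single step does not separate their contributions, and a plain benzyl group, a shorter chain such as butyl, or an amine or a carboxylic acid in place of the nitrile on the ring would each bear on that question. Compound 4 differs from compound 3 in more than one place, so how much of the value of compound 3, 141%, comes from the group on this nitrogen cannot be read from these compounds.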